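Chain extension at the hydrazone carbon: compound 2 to compound 3

The compounds below may be only part of what the source reports. "The series", "measured", "known", "first", "only" and "open" are said of these compounds alone.

Compound 1 `CC/C(C)=N\Nc1nc(-c2cccc([N+](=O)[O-])c2)cs1` carries an ethyl arm on the hydrazone carbon; in an assay on isolated protein for inhibition of Amine oxidase [flavin-containing] A (Homo sapiens), read by fluorescence, with a stated time of 20 min (on this read-out higher numbers stand for weaker inhibition and lower numbers for stronger inhibition), compound 1 gives 20500 nM. Compound 2 `C=CCC/C(C)=N\Nc1nc(-c2cccc([N+](=O)[O-])c2)cs1` extends that arm with a vinyl and in this assay compound 2 gives 3990 nM. The step is a 5.1-fold lower number from compound 1 to compound 2 (0.71 log units; beyond the scatter). For the measured compounds named here, on the numbers so far compound 2 holds the lowest value of the pair, with compound 1 as its only neighbour and a clearly higher number.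

Compound 3 `CCCCCC/C(C)=N\Nc1nc(-c2cccc([N+](=O)[O-])c2)cs1` differs from compound 2 by butyl in place of vinyl on a saturated chain carbon, two bonds along the chain from a carbon with a double bond to nitrogen. Going by the values given here, the only measured step that bears on this change is the one from compound 1 to compound 2, where lengthening the same arm gave a modest lowering. Among the compounds with values here, that step carried a vinyl in; here a saturated butyl replaces it, so a further lengthening of the arm with no measured precedent for the loss of the double bond. The expectation for compound 3 in this assay is therefore a number near that of compound 2, leaning lower rather than higher, with a step of about a 1.6-fold lower number from compound 2 to compound 3 (0.20 log units; within the scatter) expected. For compound 3 the estimate is 2500 nM, with a range from 700 nM to 9000 nM.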

Compound 3, half-maximal inhibitory concentration: 10900 nM
Beside the measured number, compound 3's estimate is 4.4-fold (0.64 log units) below it; measured number above the stated range.
By their numbers in this assay, from the lowest: compound 2; then compounds 3 and 1 (each within the scatter of the next).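

In this assay the butyl for vinyl change gives a 2.7-fold higher number from compound 2 to compound 3 (0.44 log units; beyond the scatter) and so reverses the gain seen on first extending this arm: lengthening at this position does not lower the number by itself. Set against the ethyl arm, the butyl in place of hydrogen gives a 1.9-fold lower number from compound 1 to compound 3 (0.27 log units; within the scatter) and leaves compound 3 not separable from compound 1, whereas compound 2, with its but-3-en-1-yl arm, is the strongest inhibitor of the three, its steps to both others being beyond the scatter. No supporting data bear on why the unsaturated arm stands apart from the saturated ones.

Compound 2 and compound 3 differ both in the double bond and in arm length, so the contribution of each remains unresolved, and a plain butyl arm in place of but-3-en-1-yl would separate the two. Also open, from the compounds shown here alone, is how this position responds to a terminal alkyne or a hydroxyl at the end of the arm, or to a chain longer than hexyl.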